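Removing the cyano group from compound 3

The source may report more compounds than this note shows. Statements on the series, on what has been measured and on what is new or still open speak of the compounds shown alone.

Three compounds share a core and differ at one aromatic carbon. Compound 1 `CCCSc1cc(C)c(C(=O)N=C(N)N)cc1S(C)(=O)=O` carries a propylsulfanyl group there; in a functional assay for inhibition of sodium/hydrogen exchanger (Oryctolagus cuniculus) (a higher number here means a weaker inhibitor, a lower number a stronger inhibitor), compound 1 gives 6.8 nM. Compound 2 `Cc1cc(Nc2ccccc2)c(S(C)(=O)=O)cc1C(=O)N=C(N)N` carries an anilino group, and in this assay compound 2 gives 21 nM. Compound 3 `Cc1cc(C#N)c(S(C)(=O)=O)cc1C(=O)N=C(N)N` carries a cyano group, and in this assay compound 3 gives 70 nM. Compound 3 therefore stands at the weakest end of the three: the step of a 10-fold higher number from compound 1 to compound 3 (1.01 log units; beyond the scatter) is large, and the step of a 3.3-fold higher number from compound 2 to compound 3 (0.52 log units; beyond the scatter) is modest, so every substituent seen so far at this carbon does better than the cyano group.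

Compound 4 `Cc1ccc(S(C)(=O)=O)cc1C(=O)N=C(N)N` takes the change (hydrogen in place of cyano on an aromatic carbon). Within the data shown here, no measured step removes a substituent outright, so the two steps ending at compound 3 are the only guide, and they show that the group at this carbon matters, with smaller and less elaborate groups giving weaker inhibition. For compound 4 a further modest loss is therefore expected, with the step of a 1.9-fold higher number from compound 3 to compound 4 (0.27 log units; within the scatter) as the estimate, though the scatter leaves room for no change at all. Compound 4 is expected at 130 nM, in a range from 40 nM to 400 nM.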

Compound 4, half-maximal inhibitory concentration: 150 nM
The estimate for compound 4 lay 1.2-fold (0.06 log units) below the measured number; low and high end bracket the measured number.
By their numbers in this assay, from the lowest: compound 1; then compound 2; then compound 3; then compound 4.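

With compound 4 the series gains its first reference point with only hydrogen at this carbon, so the three substituents can now be read against no substituent rather than only against each other. Even the cyano group, which has just 2 heavy atoms, counts for something in this assay, since a 2.1-fold higher number from compound 3 to compound 4 (0.33 log units; beyond the scatter) lies beyond the scatter. The anilino and propylsulfanyl groups are worth more than that, as a 7.1-fold higher number from compound 2 to compound 4 (0.85 log units; beyond the scatter) and a 22-fold higher number from compound 1 to compound 4 (1.34 log units; beyond the scatter) show, which makes compound 4 the weakest of the four and places every substituent shown at this carbon, ortho to a methylsulfonyl group, ahead of hydrogen.

The compounds shown leave open whether the gain follows the size of the group or the atom that joins it to the ring, since the propylsulfanyl and anilino groups differ in both. As far as these compounds go, a methoxy group, a simple amine or a longer alkylsulfanyl chain at this carbon would help separate the two, and whether any of them would go beyond compound 1 also remains open. Nothing available here accounts for the order of these four compounds.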